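The compounds below may be only part of what the source reports. "The series", "measured", "known", "first", "only" and "open" are said of these compounds alone.

Compound 1 `Clc1cc(Cl)cc(CO[C@H]2CCCN(Cc3ccccc3)[C@H]2c2ccccc2)c1` has a benzyl on the ring amine nitrogen of the shared core. In an assay on isolated protein for activation of cGMP-dependent protein kinase 1 (Homo sapiens), read by ADP-Glo, with stated times of 120 min and 40 min (on this read-out lower numbers stand for an effect already at smaller amounts and higher numbers for an effect only at larger amounts of compound), compound 1 gives only a limit, > 200000 nM. That limit is the limit of > 200000 nM in this assay, at which 1 of the 3 values shown sits, so compound 1 stands at the far end of the numbers shown and has no value of its own. Compound 2 `OC[C@@H](O[C@H]1CCCN(Cc2ncc[nH]2)[C@H]1c1ccccc1)c1cc(Cl)cc(Cl)c1` and compound 3 `O=C(O)c1ccc(CN2CCC[C@H](O[C@H](CO)c3cc(Cl)cc(Cl)c3)[C@@H]2c2ccccc2)cc1` differ from compound 1 in more than one place and both have numbers: compound 2 gives 7000 nM in this assay, and compound 3 gives 11000 nM. The step of a 1.6-fold higher number from compound 2 to compound 3 (0.20 log units; within the scatter) shows that a carboxyphenyl on that chain carbon in place of an imidazolyl changes little.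

Compound 4 `O=C(O)c1cncc(CN2CCC[C@H](OCc3cc(Cl)cc(Cl)c3)[C@@H]2c2ccccc2)c1` differs from compound 1 by 5-carboxypyridin-3-yl in place of phenyl on a saturated chain carbon bound to an amine nitrogen in a ring. Within the data shown here, the only measured step bearing on a carboxy-bearing aromatic ring at this place is a 1.6-fold higher number from compound 2 to compound 3 (0.20 log units; within the scatter), which lies within the scatter, though it starts from a compound with a number rather than a limit. The expected step is therefore small, an at least 1.3-fold lower number from compound 1 to compound 4 (0.12 log units; that floor lies within the scatter). Compound 4 is expected to give about 150000 nM in this assay, within 30000 nM to 400000 nM, with a fair chance that only a limit is reported again.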

Compound 4, half-maximal effective concentration: 117000 nM
For compound 4 the middle estimate is 1.3-fold (0.11 log units) above the measured one; the measured number falls inside the stated range.
By their numbers in this assay, from the lowest: compounds 2 and 3 (each within the scatter of the next); then compound 4. At a limit, above all of these: compound 1.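

With 5-carboxypyridin-3-yl in place of phenyl on a saturated chain carbon bound to an amine nitrogen in a ring, a number appears in this assay where the earlier benzyl compound gave only a limit, a step of an at least 1.7-fold lower number from compound 1 to compound 4 (0.23 log units; that floor lies within the scatter). On these data alone, that step is only a floor, and its true size stays unknown: the limit of > 200000 nM in this assay, at which 1 of the 4 values shown sits. The result therefore shows that this change can bring a measurable number, but not that the shift exceeds the usual scatter.

The change swaps a ring carbon for nitrogen and adds a carboxylic acid together, so pyridin-3-yl and 3-carboxyphenyl at this place would be needed to tell the two apart. As far as these compounds go, whether a carboxamide or an amine in place of the carboxylic acid also gives a number in this assay remains open.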